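A few compounds are considered here, and "the series" means these few. Any claim that something is new, unique, unknown or untested is made for them only; others in the source may bear on it.

Measured compounds:
Compound 1, `Nc1nc(Nc2ccc(Cl)cc2)cc(-c2cc(Cl)ccc2Cl)n1`, in an assay on Sf9 cells for inhibition of 1-acyl-sn-glycerol-3-phosphate acyltransferase beta (Homo sapiens); on this read-out lower numbers stand for stronger inhibition and higher numbers for weaker inhibition: 20 nM
Compound 2, `CCOc1ccc(Cl)cc1-c1cc(Nc2ccc(Cl)cc2)nc(N)n1`, in this assay: 17 nM

Compound 2 stands alongside compound 1: the step of a 1.2-fold lower number from compound 1 to compound 2 (0.07 log units; within the scatter) lies within the scatter, so the two cannot be told apart. Compound 3, `CCOc1ccc(Cl)cc1-c1cc(Nc2ccc([N+](=O)[O-])cc2)nc(N)n1`, has not yet been measured. It differs from compound 2 by nitro in place of chloro on an aromatic carbon. Going by the values given here, the only measured step, a 1.2-fold lower number from compound 1 to compound 2 (0.07 log units; within the scatter), concerns a different exchange, ethoxy for chloro, elsewhere in the molecule, and does not speak to a nitro group. With no guide, the expected step in this assay, a 1.2-fold higher number from compound 2 to compound 3 (0.07 log units; within the scatter), is none beyond the scatter. Compound 3 is therefore estimated at 20 nM, ranging from 7 nM to 60 nM.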

Compound 3, half-maximal inhibitory concentration: 10 nM
Estimate against measurement, compound 3: 2.0-fold (0.30 log units) above; the range from low to high includes it.
By their numbers in this assay, from the lowest: compounds 3, 2 and 1 (each within the scatter of the next).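

Going from 4-chlorophenyl to 4-nitrophenyl with the ethoxy group kept gives a 1.7-fold lower number from compound 2 to compound 3 (0.23 log units; within the scatter) in this assay and so leaves the two compounds indistinguishable. This is the first change shown at this position, and it shows that a chloro group of one heavy atom and a nitro group of three, with its two hydrogen-bond acceptors, cannot be separated here. As far as these compounds go, whether an amine or a carboxylic acid at this position would read the same stays open, as does whether nitro behaves alike with chloro in place of ethoxy. Nothing measured here offers an explanation of this result.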